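The compounds below may be only part of what the source reports. "The series", "measured", "known", "first", "only" and "open" are said of these compounds alone.

Compound 1 `Cc1cn([C@@H]2O[C@H](CO[Si](C)(C)C(C)(C)C)[C@@]3(OS(=O)(=O)C=C3N)[C@H]2O[Si](C)(C)C(C)(C)C)c(=O)nc1N` in a functional assay on MT4 cells (Homo sapiens) for cytotoxicity (on this read-out lower numbers stand for higher toxicity in this test and higher numbers for lower toxicity in this test), gives 31000 nM.
Compound 2 `CC(C)(C)[Si](C)(C)OC[C@H]1O[C@@H](n2ccc(N)nc2=O)[C@H](O[Si](C)(C)C(C)(C)C)[C@]12OS(=O)(=O)C=C2N` reaches only a limit, > 360000 nM.
Compound 3 `CCn1c(=O)c(C)cn([C@@H]2O[C@H](CO[Si](C)(C)C(C)(C)C)[C@@]3(OS(=O)(=O)C=C3N)[C@H]2O[Si](C)(C)C(C)(C)C)c1=O` gives 123000 nM.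

Compound 3 thus stands at the highest of the two numbers actually read in this assay, separated from its nearest neighbour by a 4.0-fold higher number from compound 1 to compound 3 (0.60 log units; beyond the scatter). The other measured value is a limit, (the limit of > 360000 nM in this assay, at which 1 of the 3 values shown sits).

Compound 4 `CC(C)=CCn1c(=O)c(C)cn([C@@H]2O[C@H](CO[Si](C)(C)C(C)(C)C)[C@@]3(OS(=O)(=O)C=C3N)[C@H]2O[Si](C)(C)C(C)(C)C)c1=O` differs from compound 3 by 2-methylprop-1-en-1-yl in place of methyl on a saturated chain carbon bound to an aromatic nitrogen. Among the compounds with values here, no measured step alters this chain alone; the steps of a 4.0-fold higher number from compound 1 to compound 3 (0.60 log units; beyond the scatter) and an at least 2.9-fold lower number from compound 2 to compound 3 (0.46 log units; beyond the scatter) exchange the whole group carrying it, so they bear on the change only loosely. A modest move toward a lower number is expected, a 1.5-fold lower number from compound 3 to compound 4 (0.19 log units; within the scatter). Compound 4 is therefore estimated at 80000 nM, with a range from 25000 nM to 250000 nM.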

Compound 4, half-maximal cytotoxic concentration: 69000 nM
The estimate for compound 4 lay 1.2-fold (0.06 log units) above the measured number; the range from low to high includes it.
By their numbers in this assay, from the lowest: compound 1; then compounds 4 and 3 (each within the scatter of the next). At a limit, above all of these: compound 2.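

In this assay, within the data shown here, the step of a 1.8-fold lower number from compound 3 to compound 4 (0.25 log units; within the scatter) is the first to alter only the chain on the aromatic nitrogen, whereas the earlier steps exchanged the whole group carrying it. Going from ethyl to 3-methylbut-2-en-1-yl at this place therefore leaves compound 4 unresolved from compound 3. Nothing shown accounts for this result.

As far as these compounds go, whether an amine, a carboxylic acid or a longer saturated chain at this place would move the number beyond the scatter stays open. So does whether this chain would read the same with hydrogen in place of methyl on the aromatic carbon, as in compound 2.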